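A few compounds are considered here, and "the series" means these few. Any claim that something is new, unique, unknown or untested is made for them only; others in the source may bear on it.

Measured compounds:

- compound 1 `C[C@H](C(=O)NCc1ccc(C(F)(F)F)nc1N1CC[C@@H](N(C)C)C1)c1ccc(NS(C)(=O)=O)c(F)c1`: in a functional assay on CHO-K1 cells for antagonist activity at transient receptor potential cation channel subfamily V member 1 (Homo sapiens), read by FLIPR (on this read-out lower numbers stand for stronger inhibition and higher numbers for weaker inhibition), compound 1 gives 101 nM
- compound 2 `C[C@H](C(=O)NCc1ccc(C(F)(F)F)nc1N1CC[C@H](N(C)C)C1)c1ccc(NS(C)(=O)=O)c(F)c1`: in this assay compound 2 gives 103 nM
- compound 3 `CC(C(=O)NCc1ccc(C(F)(F)F)nc1N1CCC(c2ccccc2)CC1)c1ccc(NS(C)(=O)=O)c(F)c1`: in this assay compound 3 gives 0.6 nM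

Compound 3 stands lowest of the three numbers, and its gap to both compound 1 and compound 2 lies beyond the scatter, so it is the strongest inhibitor among the measured compounds. Compound 3, however, is drawn with one stereocentre left open, so its value belongs to a mixture. Compound 4 `C[C@H](C(=O)NCc1ccc(C(F)(F)F)nc1N1CCC(c2ccccc2)CC1)c1ccc(NS(C)(=O)=O)c(F)c1` is a single form of it: the two compounds have the same atoms and bonds; at least one stereo element is drawn with a configuration in one of them and without one in the other: 1 of 1 stereo elements differ; a stereocentre at a saturated chain carbon is drawn without a configuration in compound 3 and S in compound 4.

Among the measured compounds shown here, only one measured step touches configuration. Compounds 1 and 2 are a pair of this kind, and the move a 1.0-fold higher number from compound 1 to compound 2 (0.01 log units; within the scatter) shows no change at all, which rests on (the fact that compounds 1 and 2 differ only in the configuration as drawn). That pair, though, concerns a stereocentre at a saturated ring carbon, not the chain carbon that is fixed in compound 4, so it offers a weak guide. A single form of a mixture usually gives a number near the mixture, or somewhat lower if the other form contributes little.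

For compound 4 a small downward step a 1.5-fold lower number from compound 3 to compound 4 (0.18 log units; within the scatter) is therefore expected, within or just beyond the scatter. The estimate for compound 4 in this assay is 0.4 nM, with a range from 0.15 nM to 3 nM.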

Compound 4, inhibition constant: 0.3 nM
Beside the measured number, compound 4's estimate is 1.3-fold (0.12 log units) above it; measured number inside the range.
By their numbers in this assay, from the lowest: compounds 4 and 3 (each within the scatter of the next); then compounds 1 and 2 (each within the scatter of the next).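

In this assay, drawing the saturated chain carbon as S gives a 2.0-fold lower number from compound 3 to compound 4 (0.30 log units; within the scatter), so on this read-out the single S form cannot be told apart from the mixture: the fact that one of compounds 3 and 4 is drawn with a defined configuration and the other without, at the place where they differ. Compound 4 also allows the ring swap to be read with that chain carbon drawn S on both sides, where 4-phenylpiperidin-1-yl replaces 3-(dimethylamino)pyrrolidin-1-yl on the aromatic carbon: the result is a 340-fold lower number from compound 2 to compound 4 (2.54 log units; beyond the scatter) and also a 340-fold lower number from compound 1 to compound 4 (2.53 log units; beyond the scatter). These two large steps start from either configuration of the pyrrolidine ring carbon, and the change of the whole group at this place far outweighs the change at that ring carbon, which is only a 1.0-fold higher number from compound 1 to compound 2 (0.01 log units; within the scatter).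

On these data alone, how the R form at the chain carbon compares with compound 4 stays open, so the part played by that stereocentre is still unknown. Also open, as far as these compounds go, is how much of the large step belongs to the phenyl group and how much to the piperidine ring, which groups such as 4-cyclohexylpiperidin-1-yl or 3-phenylpyrrolidin-1-yl at the same place would help to separate.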